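The source may hold more compounds than are shown below. What is called first, only, known or untested is meant among the compounds shown, and "the series" means these compounds.

Compounds measured so far:

compound 1, `Cc1ccccc1-c1cc2cc(CCC(=O)O)ccc2[nH]1` — in a functional assay on CHO cells for agonist activity at Free fatty acid receptor 1 (Homo sapiens), read by a luciferase reporter, with a stated time of 24 h (a higher number here means that more compound is needed for the effect, a lower number that less compound is needed), compound 1 gives 447 nM
compound 2, `O=C(O)CCc1ccc2[nH]c(-c3ccccc3OC(F)(F)F)cc2c1` — in this assay compound 2 gives 1020 nM

Compound 2 stands at the highest of the two numbers; the nearest is compound 1, and the step of a 2.3-fold higher number from compound 1 to compound 2 (0.36 log units; beyond the scatter) is beyond the scatter. The next compound, compound 3, `O=C(O)CCc1ccc2[nH]c(-c3ccccc3Cl)cc2c1`, is not yet measured in this assay. It differs from compound 2 in one place: chloro in place of trifluoromethoxy on an aromatic carbon, on an aromatic carbon of a six-membered aromatic ring of carbon only, ortho to a large group.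

Among the measured compounds shown here, no measured step covers a chloro at this position. For the measured compounds named here, the only step that bears on the site is the one from methyl to trifluoromethoxy, a 2.3-fold higher number from compound 1 to compound 2 (0.36 log units; beyond the scatter), which sets the spread seen so far between two substituents there. Compound 3 is therefore expected to land within that spread, and the estimated step of a 1.7-fold lower number from compound 2 to compound 3 (0.23 log units; within the scatter) is a modest move toward a lower number, possibly still within the scatter. For compound 3 the value in this assay is estimated at 600 nM, with a range from 250 nM to 1400 nM.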

Compound 3, half-maximal effective concentration: 54.6 nM
Beside the measured number, compound 3's estimate is 11-fold (1.04 log units) above it, and the stated range ends above it.
By their numbers in this assay, from the lowest: compound 3; then compound 1; then compound 2.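

In this assay the group on this aromatic carbon, ortho to a large group, matters more than the step from methyl to trifluoromethoxy alone showed. Chloro in place of trifluoromethoxy gives a 19-fold lower number from compound 2 to compound 3 (1.27 log units; beyond the scatter) and chloro in place of methyl gives an 8.2-fold lower number from compound 1 to compound 3 (0.91 log units; beyond the scatter) as a further move, so the spread at this position is now much wider. Compound 3 holds the lowest number of the three, with both of its steps beyond the scatter, and nothing here explains why chloro stands apart from the other two groups.

On these data alone, three groups at one position give a rank order and not a trend, so it remains open whether fluoro, bromo, methoxy or trifluoromethyl at the same place would fall with chloro or with the other two groups. Also open, as far as these compounds go, is whether the low number of compound 3 depends on chloro being ortho to a large group, which chloro on another carbon of that ring would test, and whether it survives when the propanoic acid chain is replaced by a longer chain or an amide.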